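A few compounds are considered here, and "the series" means these few. Any claim that something is new, unique, unknown or untested is made for them only; others in the source may bear on it.

- compound 1 `COC(=O)C1=C(C)NC(C)=C(C(=O)OC)C1c1c(-c2ccccn2)nc2sc(C)cn12`: 2810 nM
- compound 2 `COC(=O)C1=C(C)NC(C)=C(C(=O)OC)C1c1c(-c2ccncc2)nc2sc(C)cn12`: 9690 nM
- compound 3 `COC(=O)C1=C(C)NC(C)=C(C(=O)OC)C1c1c(-c2cccs2)nc2sc(C)cn12`: 1370 nM

In a functional assay on ileum (Cavia porcellus) for inhibition (on this read-out higher numbers stand for weaker inhibition and lower numbers for stronger inhibition), compound 2 gives 9690 nM, the highest of the three numbers and so the weakest inhibition measured here. Compound 4 `COC(=O)C1=C(C)NC(C)=C(C(=O)OC)C1c1c(-c2ccncc2)nc2sccn12` differs from it in one place: hydrogen in place of methyl on an aromatic carbon. Within the data shown here, no measured pair tests this change directly. The three measured steps swap the aromatic group instead: a 3.4-fold higher number from compound 1 to compound 2 (0.54 log units; beyond the scatter), a 2.1-fold lower number from compound 1 to compound 3 (0.31 log units; beyond the scatter) and a 7.1-fold lower number from compound 2 to compound 3 (0.85 log units; beyond the scatter). Among the measured compounds shown here, they show only that one change on this core can shift the number modestly, so a modest step is expected. From the compounds shown here alone, its direction remains open, with a slight lean downward, as compound 2 at 9690 nM already tops the set. The estimated step is a 1.5-fold lower number from compound 2 to compound 4 (0.17 log units; within the scatter). For compound 4 the expected value is 6500 nM, with an estimated range from 1800 nM to 22000 nM.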

Compound 4, half-maximal inhibitory concentration: 960 nM
Compound 4: middle estimate off by 6.8-fold (0.83 log units), on the high side; the whole stated range lies above it.
By their numbers in this assay, from the lowest: compounds 4 and 3 (each within the scatter of the next); then compound 1; then compound 2.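

In this assay, hydrogen in place of methyl on the aromatic carbon next to the ring sulfur gives a 10-fold lower number from compound 2 to compound 4 (1.00 log units; beyond the scatter) and so strengthens inhibition. This single-carbon change moves the number about as far as the largest exchange of the aromatic group, which gives a 7.1-fold lower number from compound 2 to compound 3 (0.85 log units; beyond the scatter) on the same core. No measurement shown explains why this position responds so strongly. From the compounds shown here alone, whether the same change gives a similar step with pyridin-2-yl or thiophen-2-yl on the core remains open, as does the effect of an ethyl group or a chlorine atom on this carbon.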